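Methoxy in Place of Aminoamino: From Compound 2 to Compound 4

The compounds below may be only part of what the source reports. "The series", "measured", "known", "first", "only" and "open" are said of these compounds alone.

Three compounds have been measured in an assay on a protein complex for inhibition of CDK8/Cyclin C (Homo sapiens), with a stated time of 1 h, tested at 10 uM; a lower number here means less inhibition, a higher number more inhibition at the concentration tested (going by the name of the read-out):
compound 1 `CCOC(=O)/C=C/c1ccncc1-c1ccc2c(cnn2C)c1` gives 100%;
compound 3 `CN1CCN(C(=O)/C=C/c2ccncc2-c2ccc(F)cc2)CC1` gives 84%;
compound 2 `NNC(=O)COc1ccncc1-c1ccc2ccccc2c1` gives 19%.

Compound 2 stands lowest of the three numbers in this assay. Its nearest neighbour is compound 3, whose number is higher by more than the scatter, and compound 1 lies further still, also beyond the scatter. Compound 4 `COC(=O)COc1ccncc1-c1ccc2ccccc2c1` has not yet been measured. It differs from compound 2 in a single place: methoxy in place of aminoamino on a carbonyl carbon. Within the data shown here, no two measured compounds differ in only one place, so no measured step guides this change. One expects a small upward step here, a number 11 percentage points higher from compound 2 to compound 4 (beyond the scatter), which may still fall within the scatter. Compound 4 is therefore estimated at 30%, with a range from 5% to 65%.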

Compound 4, a percentage reported as inhibition, at one concentration (the size of the read-out at that concentration, not a potency): 11%
Beside the measured number, compound 4's estimate is 19 percentage points above it, and the stated range covers the measured number.
By their numbers in this assay, from the lowest: compounds 4 and 2 (each within the scatter of the next); then compound 3; then compound 1.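

In this assay, among these compounds, methoxy in place of aminoamino on a carbonyl carbon gives a number 8 percentage points lower from compound 2 to compound 4 (within the scatter) and is the first step here that changes a single place. Hydrogen-bond donors are present in aminoamino and absent from methoxy, yet for this pair that difference leaves the two numbers within the scatter. Nothing measured here explains this result.

The compounds shown leave open how an amine or a carboxylic acid on this carbonyl carbon would read. As far as these compounds go, whether a longer chain would read differently also remains open.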